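A few compounds are considered here, and "the series" means these few. Any claim that something is new, unique, unknown or untested is made for them only; others in the source may bear on it.

Within the data shown here, compound 2 `COc1ccc(C(=O)/C=C/c2cc(-c3cc(OC)c(OC)c(OC)c3)n[nH]2)cc1` gives 2320 nM in a functional assay on K562 cells (Homo sapiens) for inhibition, read by sulforhodamine B assay, with a stated time of 48 h (on this read-out higher numbers stand for weaker inhibition of growth and lower numbers for stronger inhibition of growth), the lower of the two numbers so far; compound 1 `COc1cc(-c2cc(/C=C/C(=O)c3ccc(Cl)c(Cl)c3)[nH]n2)cc(OC)c1OC` gives 4960 nM in this assay. Among the measured compounds shown here, the single measured step, a 2.1-fold lower number from compound 1 to compound 2 (0.33 log units; beyond the scatter), is the only one that bears on the move to compound 3 `COc1cc(-c2cc(/C=C/C(=O)c3ccc(F)c(F)c3)[nH]n2)cc(OC)c1OC`, whose change is 3,4-difluorophenyl in place of 4-methoxyphenyl on a carbonyl carbon. With the 4-methoxyphenyl leaving the carbonyl carbon and a 3,4-difluorophenyl entering, the nearest measured kin of compound 3 is compound 1 with its 3,4-dichlorophenyl. A step back toward the number of compound 1 is therefore expected, a higher number and probably beyond the scatter, though the 3,4-difluorophenyl and the 3,4-dichlorophenyl are not the same group and the size of the step is uncertain. Compound 3 is expected at 4200 nM, between 2000 nM and 9000 nM, an expected step of a 1.8-fold higher number from compound 2 to compound 3 (0.26 log units; within the scatter).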

Compound 3, concentration for 50% growth inhibition: 3310 nM
Compound 3: middle estimate off by 1.3-fold (0.10 log units), on the high side; the range from low to high includes it.
By their numbers in this assay, from the lowest: compounds 2, 3 and 1 (each within the scatter of the next, the first and the last beyond it).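

On the carbonyl carbon, 3,4-difluorophenyl in place of 4-methoxyphenyl gives a 1.4-fold higher number from compound 2 to compound 3 (0.15 log units; within the scatter) in this assay and 3,4-difluorophenyl in place of 3,4-dichlorophenyl gives a 1.5-fold lower number from compound 1 to compound 3 (0.18 log units; within the scatter) on the same read-out. Compound 3 therefore cannot be separated from either compound 1 or compound 2, even though those two lie beyond the scatter of each other, so the only gap at this position that exceeds the scatter rests on the two ends of a run of three compounds. Nothing on hand accounts for these numbers.

Going by these compounds, whether this position keeps its numbers with something other than a substituted phenyl remains open, for example a group carrying an amine or a carboxylic acid. The compounds shown also leave open how far the numbers would move with a longer chain in place of the methoxy groups on the shared core.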